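The compounds below may be only part of what the source reports. "The series", "measured", "known", "first", "only" and "open" are said of these compounds alone.

In a functional assay on Caco-2 cells (Homo sapiens) for inhibition, read by MTT assay, with a stated time of 48 h, tested at 10 uM (a higher number here means more inhibition of growth at the concentration tested, a lower number less inhibition of growth), the measured compounds read as follows:

Compound 1 `Cc1cc(=O)c2c(O)cc(OCc3ccc(Br)cc3)c([C@H]3CCN(C)C[C@H]3O)c2o1` gives 13%
Compound 2 `Cc1cc(=O)c2c(O)cc(OCc3ccc([N+](=O)[O-])cc3)c([C@H]3CCN(C)C[C@H]3O)c2o1` gives 14%
Compound 3 `Cc1oc2c([C@H]3CCN(C)C[C@H]3O)c(O)cc(O)c2c(=O)c1C(O)c1ccc(F)c(Br)c1` gives 6%

Compound 3 at 6% lies within the scatter of both compound 1 and compound 2, so the three values cannot be ranked. The next compound is compound 4 `Cc1oc2c([C@H]3CCN(C)C[C@H]3O)c(O)cc(O)c2c(=O)c1C(O)c1ccc(F)cc1`, which differs from compound 3 by hydrogen in place of bromo on an aromatic carbon and so carries hydrogen in place of bromo on an aromatic carbon, with 3-bromo-4-fluorophenyl becoming 4-fluorophenyl. Within the data shown here, no measured step makes this exact replacement. The nearest evidence is a number 1 percentage points higher from compound 1 to compound 2 (within the scatter) for nitro in place of bromo on an aromatic carbon. That step also removes a bromo, but it brings in a different group in a different pair of compounds, so it bears on the change only loosely. No change beyond the scatter is therefore expected in this assay, and no direction can be favoured. The estimated step is a number 2 percentage points higher from compound 3 to compound 4 (within the scatter) in this expectation. For compound 4 the expected value is 8% with an estimated range from 0% to 17% in this assay.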

Compound 4, percent growth inhibition at one concentration: 11%
The estimate for compound 4 lay 3 percentage points below the measured number; low and high end bracket the measured number.
By their numbers in this assay, from the lowest: compounds 3, 4, 1 and 2 (each within the scatter of the next).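

Among these compounds, replacing the bromo of the 3-bromo-4-fluorophenyl group with hydrogen gives the first direct reading at this aromatic carbon, ortho to a fluoro group, and in this assay it amounts to a number 5 percentage points higher from compound 3 to compound 4 (within the scatter). The 4-fluorophenyl compound therefore cannot be told apart from its brominated partner, so this assay gives no sign that the bromo at this position matters for growth inhibition at the concentration tested. No measurement available here accounts for the size of this step.

The compounds shown leave open whether a methoxy group or an amine on this same aromatic carbon would give a step beyond the scatter. They also leave open whether replacing the remaining fluoro with hydrogen would do so.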